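Swapping the aryl amide: from dimethoxyphenyl to difluorophenyl

The source may report more compounds than this note shows. Statements on the series, on what has been measured and on what is new or still open speak of the compounds shown alone.

Compound 1 `COc1ccc(C(=O)Nc2ccc(C(=O)/C=C/c3nc(C)c(C)nc3C)cc2)cc1OC` is one of two compounds tested in a functional assay on MDA-MB-231 cells (Homo sapiens) for antiproliferative activity, read by CCK-8 assay, with a stated time of 72 h; on this read-out higher numbers stand for weaker inhibition and lower numbers for stronger inhibition. In this assay compound 1 gives 3360 nM, the highest of the two numbers recorded. Its nearest neighbour is compound 2 `Cc1ccc(C(=O)Nc2ccc(C(=O)/C=C/c3nc(C)c(C)nc3C)cc2)cc1`, which in this assay gives 1780 nM; the step of a 1.9-fold lower number from compound 1 to compound 2 (0.28 log units; within the scatter) stays within the scatter, so the two cannot be ordered.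

Compound 3 `Cc1nc(C)c(/C=C/C(=O)c2ccc(NC(=O)c3ccc(F)cc3F)cc2)nc1C` differs from compound 1 in one place: 2,4-difluorophenyl in place of 3,4-dimethoxyphenyl on a carbonyl carbon. Within the data shown here, the only step that bears on this change is the one from compound 1 to compound 2, where another aryl group replaced the same 3,4-dimethoxyphenyl on the carbonyl carbon and moved the number by less than the scatter. A step of similar size, if any, is therefore expected for compound 3, with no clear direction beyond the scatter. Compound 3 is expected to give about 2300 nM in this assay, within a range of 900 nM to 6000 nM, which corresponds to an expected step of a 1.5-fold lower number from compound 1 to compound 3 (0.16 log units; within the scatter).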

Compound 3, half-maximal inhibitory concentration: 1770 nM
Compound 3: middle estimate off by 1.3-fold (0.11 log units), on the high side; measured number inside the range.
By their numbers in this assay, from the lowest: compounds 3, 2 and 1 (each within the scatter of the next).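

Placing 2,4-difluorophenyl on this carbonyl carbon in place of 3,4-dimethoxyphenyl gives a 1.9-fold lower number from compound 1 to compound 3 (0.28 log units; within the scatter) in this assay, so a second replacement at this position also stays short of a clear change. The step of a 1.0-fold lower number from compound 2 to compound 3 (0.00 log units; within the scatter) adds the direct comparison of the two replacements, and all three aryl groups shown now lie within the scatter of one another, with no compound here going against that. Nothing available explains this result.

The compounds shown leave open whether any change on this carbonyl carbon can move the number beyond the scatter. An amine, a carboxylic acid or a longer alkyl chain in place of the aryl group would test this, as would a cyclohexyl ring.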